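Dichloro to monochloro on the fused core of compound 2

This account rests on a few compounds, and the source may have more. Where it says the series, first, only, none or still open, it means among the compounds named here.

Compound 2 `ClCc1ccccc1Cn1cnc2c(Cl)nc(Cl)nc21` carries two chloro groups on its fused core; in a functional assay on SNB-19 cells (Homo sapiens) for cytotoxicity, read by sulforhodamine B assay, with a stated time of 48 h (a lower number here means a stronger inhibitor of growth, a higher number a weaker inhibitor of growth), compound 2 gives "not determined" (no result reported), so it sets no reference point of its own. Among the measured compounds shown here, the only measured member of the series is compound 1 `ClCc1ccc(Cn2cnc3c(Cl)ncnc32)cc1`, which in this assay compound 1 gives 3630 nM. Compound 3 `ClCc1ccccc1Cn1cnc2c(Cl)ncnc21` is obtained from compound 2 by hydrogen in place of chloro on an aromatic carbon. For the measured compounds named here, no measured pair in this set shows what removing a chloro at such a position does, so the size and direction of the step from compound 2 to compound 3 in this assay cannot be read from the data; the working assumption is a step that does not exceed the scatter, with neither direction favoured. Compound 3 shares with compound 1 the monochloro core and the chloromethyl group on the pendant ring, and this closeness is the only anchor. Compound 3 is therefore expected to give about 4000 nM in this assay, because compound 1 gives 3630 nM; the range 1300 nM to 12000 nM is estimated to cover it.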

Compound 3, concentration for 50% growth inhibition: 5370 nM
Compound 3: the middle estimate sits 1.3-fold (0.13 log units) below what was measured; the measured number falls inside the stated range.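

In this assay compound 2 has no number to set against compound 3 at 5370 nM and so no new step can be read. Nothing in the data shown offers an explanation for the value of compound 3. As far as these compounds go, the size and direction of the change on replacing chloro with hydrogen on the core remain open.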